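The source may hold more compounds than are shown below. What is called first, only, known or untested is meant among the compounds shown, and "the series" means these compounds.

Working notes on the series. Compound 1 `O=C(/C=C/c1ccc(Oc2ncnc3ccc(Cl)cc23)cc1)/C=C/c1cc([N+](=O)[O-])ccc1Cl` is one of three measured members; in a functional assay on PC-3 cells (Homo sapiens) for inhibition, read by MTT assay, with a stated time of 72 h (on this read-out higher numbers stand for weaker inhibition and lower numbers for stronger inhibition), compound 1 gives 3150 nM. Compound 3 `O=C(/C=C/c1cc([N+](=O)[O-])ccc1Cl)/C=C/c1ccccc1Oc1ncnc2ccc(Cl)cc12` gives 2510 nM in this assay, a gap to compound 1 that lies within the usual scatter. Compound 2 `O=C(/C=C/c1ccc(Cl)c([N+](=O)[O-])c1)/C=C/c1ccccc1Oc1ncnc2ccc(Cl)cc12` gives 9760 nM in this assay, which lies beyond the scatter from compound 1, so compound 1 sits between the other two numbers, close to compound 3.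

The unmeasured compound 4 `O=C(/C=C/c1ccc(Oc2ncnc3ccc(Cl)cc23)cc1)/C=C/c1cccc(Cl)c1Cl` differs from compound 1 at one place: 2,3-dichlorophenyl in place of 2-chloro-5-nitrophenyl on a double-bonded chain carbon bound to a double-bonded chain carbon. Among the measured compounds shown here, the only measured step within the set, a 3.9-fold lower number from compound 2 to compound 3 (0.59 log units; beyond the scatter), changes the substitution pattern of the aryl ring at the same chain position and is modest in size. For the measured compounds named here, no measured pair removes the nitro group from that ring, so the direction of the present change has no direct precedent in these compounds; the one measured step shows that changes at this position move the number by a modest amount.

For compound 4 a step of a 1.4-fold higher number from compound 1 to compound 4 (0.15 log units; within the scatter) in this assay is therefore expected, with the number more likely a little higher than that of compound 1 than lower, and the estimate for compound 4 is 4500 nM, in a range from 1500 nM to 14000 nM.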

Compound 4, half-maximal inhibitory concentration: 10200 nM
Estimate against measurement, compound 4: 2.3-fold (0.36 log units) below, within the range that was stated.
By their numbers in this assay, from the lowest: compounds 3 and 1 (each within the scatter of the next); then compounds 2 and 4 (each within the scatter of the next).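

Among the compounds shown here, with 2,3-dichlorophenyl in place of 2-chloro-5-nitrophenyl on a double-bonded chain carbon bound to a double-bonded chain carbon, this assay gives a 3.2-fold higher number from compound 1 to compound 4 (0.51 log units; beyond the scatter), the first step here in which the nitro group leaves this ring. The earlier step, a 3.9-fold lower number from compound 2 to compound 3 (0.59 log units; beyond the scatter), only moved substituents around a ring that kept its nitro group, so the position now shows a direction for this exchange of groups: the number rises, by a modest step of the same class as the earlier one, and the nitro-bearing ring goes with the lower number in this pair. The step combines two changes, since the nitro group leaves and a second chlorine enters, and the measurements at hand offer nothing that explains it.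

The compounds shown leave open how much of the step belongs to the loss of the nitro group and how much to the added chlorine, and whether an amine or a carboxylic acid in its place would give a lower or a higher number. Also open, from the compounds shown here alone, is whether the same exchange on the core of compound 3 gives a step of similar size and direction, as this one is read on the core of compound 1 alone.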